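The compounds below may be only part of what the source reports. "The series", "measured", "known", "first", "only" and "open" are said of these compounds alone.

Measured so far in a functional assay on MDA-MB-231 cells (Homo sapiens) for antiproliferative activity, read by MTT assay; on this read-out higher numbers stand for weaker inhibition and lower numbers for stronger inhibition: compound 1 `CCCCC/C=C\C/C=C\CCCCCCCc1cc(=O)c2c(O)c(C)c(OCOC)c(C)c2o1` gives 16100 nM, and compound 2 `CC/C=C\C/C=C\C/C=C\CCCCCCCc1cc(=O)c2c(O)c(C)c(OCOC)c(C)c2o1` gives 16100 nM. Compound 3 `CCCCC/C=C\C/C=C\CCCCCCCc1cc(=O)c2c(O)c(C)c(OCOC)cc2o1` returns only a limit of the assay, > 87000 nM.

Compound 1 and compound 2 differ by but-1-en-1-yl in place of butyl on a saturated chain carbon bound to a double-bonded chain carbon, and this change made no change at the digits printed from compound 1 to compound 2 (within the scatter). Compound 1 and compound 3 differ in their core by hydrogen in place of methyl on an aromatic carbon; here the result was an at least 5.4-fold higher number from compound 1 to compound 3 (0.73 log units; beyond the scatter), a step that ends at the limit of > 87000 nM in this assay, at which 1 of the 3 values shown sits.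

Compound 4 `CC/C=C\C/C=C\C/C=C\CCCCCCCc1cc(=O)c2c(O)c(C)c(OCOC)cc2o1` has not yet been measured in this assay. It differs from compound 3 by but-1-en-1-yl in place of butyl on a saturated chain carbon bound to a double-bonded chain carbon, the same change that separates compound 1 from compound 2, at a place described in the same words. That change gave no change at the digits printed from compound 1 to compound 2 (within the scatter) the first time, so there is no ground to expect it to move the number now either. Compound 4 is therefore expected to show a step that the limit leaves unreadable from compound 3 to compound 4, with an estimated value near 90000 nM, somewhere from 40000 nM to 200000 nM, and quite possibly once more only a limit of the assay.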

Compound 4, half-maximal inhibitory concentration: 6790 nM
Estimate against measurement, compound 4: 13-fold (1.12 log units) above; the measured number lies below the stated range.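

In this assay, but-1-en-1-yl in place of butyl gave an at least 12-fold lower number from compound 3 to compound 4 (1.10 log units; beyond the scatter), so this change did not carry over from the core of compound 1 to the core of compound 3 with the same result: the same change on two cores in this assay, no change at the digits printed (within the scatter) from compound 1 to compound 2 and an at least 12-fold lower number (1.10 log units; beyond the scatter) from compound 3 to compound 4, at least 12-fold (1.10 log units) apart, beyond the scatter of two such steps. Hydrogen in place of methyl on an aromatic carbon likewise depended on the chain, and with the longer unsaturated chain it gave a 2.4-fold lower number from compound 2 to compound 4 (0.37 log units; beyond the scatter), opposite in direction to the earlier step: the same change on two cores in this assay, an at least 5.4-fold higher number (0.73 log units; beyond the scatter) from compound 1 to compound 3 and a 2.4-fold lower number (0.37 log units; beyond the scatter) from compound 2 to compound 4, at least 12-fold (1.10 log units) apart, beyond the scatter of two such steps. Going by these compounds, compound 3 has only a limit of the assay, > 87000 nM, so the full size of its step stays unknown, and this single pair of cores does not show why the results part or how the change would behave on a further core: the limit of > 87000 nM in this assay, at which 1 of the 4 values shown sits.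

On these data alone, it remains open whether the two chains would part in the same way on a core carrying ethyl or chlorine in place of that methyl. Also open, as far as these compounds go, is how a fully saturated chain, a shorter chain or a chain ending in a carboxylic acid would stand on either core.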